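Acetyl to dimethylamino on the aryl arm of compound 1

The source may report more compounds than this note shows. Statements on the series, on what has been measured and on what is new or still open speak of the compounds shown alone.

Of the compounds shown here, three have been tested in a functional assay on SK-MEL-5 cells (Homo sapiens) for cytotoxicity, read by sulforhodamine B assay, with a stated time of 48 h, tested at 0.01 uM; on this read-out higher numbers stand for a weaker effect at the one concentration tested and lower numbers for a stronger effect. Compound 1 `COc1cc(C)cc(-c2c(-c3ccnc(-c4ccc(C(C)=O)cc4)c3)cnn2CC#N)c1` gives 94%. Compound 2 `COc1cc(C)cc(-c2nn(CC#N)cc2-c2ccc(-c3cccc(C(C)=O)c3)nc2)c1` gives 91%, and compound 3 `COc1cc(C)cc(-c2nn(CC#N)cc2-c2ccnc(-c3ccc(N(C)C)cc3)c2)c1` gives 104%. For the measured compounds named here, the three numbers sit within the scatter of one another, compound 1 in the middle of them, so no compound can be set apart as stronger or weaker at this concentration.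

Compound 4 `COc1cc(C)cc(-c2c(-c3ccnc(-c4ccc(N(C)C)cc4)c3)cnn2CC#N)c1` differs from compound 1 by dimethylamino in place of acetyl on an aromatic carbon. Going by the values given here, no measured pair shows this change directly. Because compound 3 gives 104% with the same dimethylamino group present, the step is expected to be a number 5 percentage points higher from compound 1 to compound 4 (within the scatter), nothing beyond the scatter. Compound 4 is therefore estimated at 99%, with a range from 88% to 110%.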

Compound 4, a percentage reported as activity, at one concentration (the size of the read-out at that concentration, not a potency): 19%
The estimate for compound 4 lay 80 percentage points above the measured number, and the stated range ends above it.
By their numbers in this assay, from the lowest: compound 4; then compounds 2, 1 and 3 (each within the scatter of the next, the first and the last beyond it).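

In this assay, for the compounds shown here, dimethylamino in place of acetyl on the aromatic carbon para to a large group gives a number 75 percentage points lower from compound 1 to compound 4 (beyond the scatter), the first step beyond the scatter. Both groups count 3 heavy atoms and 1 hydrogen-bond acceptor, so these counts alone do not predict the outcome at this position. Nothing available explains the step. Open, on these data alone, is whether a primary amine, methoxy or a morpholine ring on this carbon would keep the stronger effect. Also open, as far as these compounds go, is whether the effect on this aryl arm depends on the dimethylamino group specifically.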